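A few compounds are considered here, and "the series" means these few. Any claim that something is new, unique, unknown or untested is made for them only; others in the source may bear on it.

Measured compounds:

Compound 1, `Nc1ccc(/C=C2\SC(=O)N(Cc3ccc(C(F)(F)F)cc3)C2=O)cc1`: 134000 nM
Compound 2, `C=C(Br)C(=O)Nc1ccc(/C=C2\SC(=O)N(Cc3ccc(C(F)(F)F)cc3)C2=O)cc1`: 23000 nM
Compound 3, `C=C(Br)C(=O)Nc1cccc(/C=C2\SC(=O)N(Cc3ccc(C)cc3)C2=O)c1`: 1000 nM

These three compounds were tested in a functional assay on FM3A cells (Mus musculus) for cytotoxicity, read by cell counting, with a stated time of 2 days; a lower number here means a stronger inhibitor, a higher number a weaker inhibitor. In this assay compound 3 gives the lowest number of the three, with compound 2 nearest and compound 1 furthest away; both gaps lie beyond the usual scatter.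

Compounds 2 and 1 differ in one place only: hydrogen in place of (1-bromoethenyl)carbonyl on a nitrogen on an aromatic ring. That step, a 5.8-fold higher number from compound 2 to compound 1 (0.77 log units; beyond the scatter), weakened the inhibitor by a modest amount.

Compound 4, `Cc1ccc(CN2C(=O)S/C(=C\c3cccc(N)c3)C2=O)cc1`, has not yet been tested in this assay. It is made from compound 3 by the same change: hydrogen in place of (1-bromoethenyl)carbonyl on a nitrogen on an aromatic ring. Going by the values given here, compound 3 and compound 2 carry different cores, and the difference between the two cores is not broken down here, so the only guide to what the change does is the single step from compound 2 to compound 1.

On that basis, the step from compound 3 to compound 4 is expected to be a weakening of similar size to the earlier one, roughly an 8.0-fold higher number from compound 3 to compound 4 (0.90 log units; beyond the scatter), though resting on one example it could turn out larger or smaller. Compound 4 is therefore estimated at 8000 nM in this assay, with a range from 2500 nM to 40000 nM.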

Compound 4, half-maximal inhibitory concentration: 158000 nM
Compound 4: the middle estimate sits 20-fold (1.30 log units) below what was measured, outside the stated range (above it).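

Taking away the (1-bromoethenyl)carbonyl group and leaving a plain amino group weakened the inhibitor in this assay once more, this time by a large amount: a 160-fold higher number from compound 3 to compound 4 (2.20 log units; beyond the scatter). Set beside the earlier step, the direction of the change carries over from one core to the other, but its size does not: the same change on two cores in this assay, a 5.8-fold higher number (0.77 log units; beyond the scatter) from compound 2 to compound 1 and a 160-fold higher number (2.20 log units; beyond the scatter) from compound 3 to compound 4, 27-fold (1.43 log units) apart, beyond the scatter of two such steps This shows that in these two pairs the loss on removing the group depends strongly on the core that carries it, so a size measured on one core is a poor guide to the size on the other, but two pairs give no general rule and do not show which part of the core sets the size, or why.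

The compounds shown leave open how much of the loss belongs to the bromine and how much to the rest of the group, which an acetyl group, or the same ethenyl carbonyl without the bromine, on the same nitrogen could begin to separate. They also leave open how large the step would be on further cores, for instance one with a chlorine or a methoxy group in place of the methyl of compound 3.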